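This account rests on a few compounds, and the source may have more. Where it says the series, first, only, none or still open, it means among the compounds named here.

Measured so far:
compound 1, `Cc1ccc(NC(=O)N[C@H](C)c2ccccc2)cc1`: 100%
compound 2, `Cc1ccc(NC(=O)N[C@@H](C)c2ccccc2)cc1`: 100%
compound 3, `CCCCCCCc1ccc(NC(=O)N[C@@H](C)c2ccccc2)cc1`: 100%

In an ADME assay on the whole organism with Oryza sativa as the target, tested at 0.1 uM (on this read-out lower numbers stand for a stronger effect and higher numbers for a weaker effect at the one concentration tested), compound 1 stands level with compound 2 and compound 3 at the digits shown. The step of no change at the digits printed from compound 1 to compound 2 (within the scatter) compares the two configurations of the shared core, as the fact that compounds 1 and 2 differ only in the configuration as drawn records, and leaves the read-out where it was. The step of no change at the digits printed from compound 2 to compound 3 (within the scatter), hexyl in place of hydrogen on a saturated chain carbon bound to an aromatic carbon, likewise leaves the read-out unchanged within the scatter. Among the measured compounds shown here, every measured compound thus sits at the same level, and no measured step has moved the number.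

Compound 4, `C[C@@H](NC(=O)Nc1ccc(F)cc1)c1ccccc1`, is not yet measured. It differs from compound 1 by fluoro in place of methyl on an aromatic carbon. Neither measured step touches the aromatic carbon where fluoro enters; the nearest comparison is the exchange of a group on the other side of the core, the step from compound 2 to compound 3, which gave no change beyond the scatter. For the measured compounds named here, with three compounds all at one level and no step that shifted the read-out, the expectation for compound 4 is no step beyond the scatter in this assay. The expected step is a number 2 percentage points lower from compound 1 to compound 4 (within the scatter). Compound 4 is therefore estimated at 98%, within a range from 85% to 100%.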

Compound 4, a percentage reported as activity, at one concentration (the size of the read-out at that concentration, not a potency): 98%
Compound 4: middle estimate and measured number agree at the digits printed; low and high end bracket the measured number.
By their numbers in this assay, from the lowest: compounds 4, 1, 2 and 3 (each within the scatter of the next).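

In this assay, fluoro in place of methyl on an aromatic carbon, para to a large group, gives a number 2 percentage points lower from compound 1 to compound 4 (within the scatter) and so adds a third step that leaves the read-out within the scatter. The earlier steps shown here changed only a stereocentre and a saturated chain carbon, whereas this one replaces the atom bound directly to the aromatic carbon, putting fluorine where carbon stood, and so shows that the read-out at this position does not depend on that atom being carbon, at least for these two groups. Among the compounds shown here, the only supporting information on hand concerns configuration and has no bearing on this exchange, so no cause can be given for the result.

On these data alone, whether a carboxylic acid or an amine on this aromatic carbon would move the read-out beyond the scatter stays open. All four compounds sit within the scatter of one another at the single concentration tested, so the compounds shown do not reveal which change to the shared core, if any, would produce a stronger effect in this assay.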